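From a Small Saturated Ring to a Cyanophenyl Tail

The source may hold more compounds than are shown below. What is called first, only, known or untested is meant among the compounds shown, and "the series" means these compounds.

Values in an in vitro functional assay on cells for agonist activity at Bombesin receptor subtype-3 (Mus musculus), read by luminescence and calcium flux; a higher number here means that more compound is needed for the effect, a lower number that less compound is needed:
Compound 1 `O=C(O)c1ccccc1-c1ccc(CCc2ncc(CC3CCC3)[nH]2)cc1`: 7.1 nM
Compound 2 `CCCCc1cnc(C(Cc2ccc(-c3ccccc3C(=O)O)cc2)C(C)C)[nH]1`: 2240 nM
Compound 3 `CCC(C)(C)Cc1c[nH]c(CCc2ccc(-c3ccccc3C(=O)O)cc2)n1`: 9.6 nM

Compound 1 has the lowest number of the three. Compound 3 is the nearest to it, and the gap between the two lies within the scatter, so nothing separates them. Compound 2 is far away, with a number beyond the scatter; compound 2 differs from compound 1 in more than one place, so only the two values themselves can be compared.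

Compound 4 `N#Cc1ccc(Cc2cnc(CCc3ccc(-c4ccccc4C(=O)O)cc3)[nH]2)cc1` has not yet been measured in this assay. It is reached from compound 1 by one change: 4-cyanophenyl in place of cyclobutyl on a saturated chain carbon bound to an aromatic carbon. The small saturated ring at the end of the chain is swapped for a flat aromatic ring carrying a nitrile. Among the measured compounds shown here, no measured pair shows this kind of swap, so the expectation rests only on the fact that compound 1 and compound 3, which carry two rather different saturated tails, sit close together.

Compound 4 is expected to land at about 30 nM, with a range from 5 nM to 300 nM. The step this estimate means, a 4.2-fold higher number from compound 1 to compound 4 (0.63 log units; beyond the scatter), is expected to be a modest rise, possibly no more than the scatter.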

Compound 4, half-maximal effective concentration: 723 nM
Estimate against measurement, compound 4: 24-fold (1.38 log units) below; measured number outside the range, above it.
By their numbers in this assay, from the lowest: compounds 1 and 3 (each within the scatter of the next); then compound 4; then compound 2.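

In this assay, among the compounds shown here, the swap of cyclobutyl for 4-cyanophenyl on this saturated chain carbon gives a 100-fold higher number from compound 1 to compound 4 (2.01 log units; beyond the scatter) and is the first step where only one place changes. It shows that the group at the end of this chain strongly affects the result: with the flat aromatic ring and its nitrile in place of the small saturated ring, far more compound is needed for the same effect, so this position does not accept every group equally. No measurement shown here accounts for the size of this step, which therefore stands as an observation without an explanation.

The compounds shown cannot say whether the aromatic ring, the nitrile or the larger size of the new group matters most, and a plain benzyl group, with no nitrile, at the same place would begin to separate these possibilities. A cyclohexyl group would test a larger saturated ring there, while an amine on the chain would show how this position responds to a very different kind of group.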